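A few compounds are considered here, and "the series" means these few. Any claim that something is new, unique, unknown or untested is made for them only; others in the source may bear on it.

Series of enone-linked pyrazoles tested in a functional assay on A498 cells (Homo sapiens) for cytotoxicity, read by sulforhodamine B assay, with a stated time of 48 h, tested at 1 uM; a lower number here means a stronger effect, a higher number a weaker effect of the compound at the concentration tested. Compound 1 `COc1ccc(-c2cc(/C=C/C(=O)c3ccc(N)cc3)[nH]n2)cc1` gives 90% in this assay, the highest of the two numbers seen. Compound 2 `COc1ccc(C(=O)/C=C/c2cc(-c3cc(OC)c(OC)c(OC)c3)n[nH]2)cc1` gives 84% in this assay, within the scatter of compound 1. Compound 3 `COc1ccc(-c2cc(/C=C/C(=O)c3ccc(N)cc3)[nH]n2)cc1OC` is not yet measured; it differs from compound 1 by methoxy in place of hydrogen on an aromatic carbon. Among the measured compounds shown here, no step between measured compounds separates this change on its own, so in this assay the step from compound 1 to compound 3 is expected to be small, at most a slight lowering beyond the scatter, a number 5 percentage points lower from compound 1 to compound 3 (within the scatter). Compound 3 is estimated at 85%, from 70% to 98%.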

Compound 3, a percentage reported as activity, at one concentration (the size of the read-out at that concentration, not a potency): 89%
Beside the measured number, compound 3's estimate is 4 percentage points below it; measured number inside the range.
By their numbers in this assay, from the lowest: compounds 2, 3 and 1 (each within the scatter of the next).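

Methoxy in place of hydrogen on an aromatic carbon, ortho to a methoxy group and meta to a large group, is now seen as a single change: in this assay the reading is a number 1 percentage points lower from compound 1 to compound 3 (within the scatter) at this one concentration. At this position, then, the series tolerates the added methoxy without a step beyond the scatter. Nothing available accounts for this result.

As far as these compounds go, whether a hydroxy group, a fluorine atom or a longer chain such as ethoxy at this position would give a larger step remains open. Also open, from the compounds shown here alone, is whether any change here would matter at a concentration other than the one tested.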